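Swapping Chloro for Bromo at the Weakest Point

The compounds below may be only part of what the source reports. "The series", "measured", "known", "first", "only" and "open" are said of these compounds alone.

Three compounds were measured in a functional assay on MCF7 cells (Homo sapiens) for antiproliferative activity, read by MTT assay, with a stated time of 72 h; on this read-out higher numbers stand for weaker inhibition and lower numbers for stronger inhibition:

compound 1, `CCN1CCN(c2cc(C)c3cc(NC(=O)c4cccc(Cl)c4)ccc3n2)CC1`: 3820 nM
compound 2, `CCN1CCN(c2cc(C)c3cc(NC(=O)c4cccnc4)ccc3n2)CC1`: 26600 nM
compound 3, `CCN1CCN(c2cc(C)c3cc(NC(=O)c4ccccc4Cl)ccc3n2)CC1`: > 50000 nM, a limit of the assay rather than a number

Compound 3 therefore stands at the weak end of the series, as the limit of > 50000 nM in this assay, at which 1 of the 3 values shown sits, shows. The steps reaching it are an at least 13-fold higher number from compound 1 to compound 3 (1.11 log units; beyond the scatter) and an at least 1.8-fold higher number from compound 2 to compound 3 (0.27 log units; that floor lies within the scatter), both only lower bounds on how much weaker it is.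

Compound 4, `CCN1CCN(c2cc(C)c3cc(NC(=O)c4ccccc4Br)ccc3n2)CC1`, differs from compound 3 by bromo in place of chloro on an aromatic carbon. Within the data shown here, no measured step exchanges one halogen for another, so the steps to compound 3 are the only guide, and they place the starting point at the limit. The expected step is a step that the limit leaves unreadable from compound 3 to compound 4, that is, nothing beyond the scatter. Compound 4 is therefore estimated at 60000 nM, within 20000 nM to 200000 nM, and most likely again reported only as a limit.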

Compound 4, half-maximal inhibitory concentration: 27500 nM
Beside the measured number, compound 4's estimate is 2.2-fold (0.34 log units) above it; measured number inside the range.
By their numbers in this assay, from the lowest: compound 1; then compounds 2 and 4 (each within the scatter of the next). At a limit, above all of these: compound 3.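

In this assay, bromo at this position gives a readable number, whereas compound 3 with chloro stands only at a limit of the assay: the limit of > 50000 nM in this assay, at which 1 of the 4 values shown sits. From the compounds shown here alone, the change can therefore be given only as a floor, an at least 1.8-fold lower number from compound 3 to compound 4 (0.25 log units; that floor lies within the scatter), so its true size stays unknown. The 2-bromophenyl group performs like pyridin-3-yl, a 1.0-fold higher number from compound 2 to compound 4 (0.01 log units; within the scatter), but does not reach 3-chlorophenyl, a 7.2-fold higher number from compound 1 to compound 4 (0.86 log units; beyond the scatter).

Going by these compounds, how far the chloro and bromo compounds truly differ remains open. So does whether a methoxy group or an amine at this position would give a lower number.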